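This account rests on a few compounds, and the source may have more. Where it says the series, first, only, none or still open, it means among the compounds named here.

Working notes on the indole-bearing series.

Three compounds have numbers in an assay on isolated protein for inhibition of Myeloperoxidase (Homo sapiens); a higher number here means a weaker inhibitor, a lower number a stronger inhibitor. Compound 1 `Nc1ncnc2c1c(-c1ccc3cc[nH]c3c1)cn2-c1ccc(OCCNCCO)cc1` gives 220 nM. Compound 2 `CN(C)Cc1ccc(-n2cc(-c3ccc4cc[nH]c4c3)c3c(Cl)ccnc32)cc1` gives 120 nM. Compound 3 `NCCCCn1cc(-c2ccc3cc[nH]c3c2)c(C(F)(F)F)n1` gives 330 nM, the highest of the three numbers; against compound 1 the gap is within the scatter, so the two cannot be told apart, while against compound 2 the gap is beyond the scatter, compound 2 showing the lower number. For the measured compounds named here, no pair of these three differs in a single place, so no step between measured compounds can be read off.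

Compound 4 `NC(=O)Cn1cc(-c2ccc3cc[nH]c3c2)c(C(F)(F)F)n1` has not yet been measured in this assay. It differs from compound 3 in one place: carbamoyl in place of 3-aminopropyl on a saturated chain carbon bound to an aromatic nitrogen. The 3-aminopropyl chain of compound 3 is gone and a carbamoyl stands where it was, on the saturated chain carbon bound to the aromatic nitrogen.

With no measured step of this kind in the set, the expectation rests on the counted change alone. For compound 4 a step of a 1.8-fold higher number from compound 3 to compound 4 (0.26 log units; within the scatter) toward a somewhat higher number than compound 3 is expected, close to the edge of the scatter. The estimate for compound 4 in this assay is 600 nM, with a range from 200 nM to 2000 nM.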

Compound 4, half-maximal inhibitory concentration: 2000 nM
Compound 4: middle estimate off by 3.3-fold (0.52 log units), on the low side; measured number inside the range.
By their numbers in this assay, from the lowest: compounds 2, 1 and 3 (each within the scatter of the next, the first and the last beyond it); then compound 4.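

In this assay, for the compounds shown here, the saturated chain carbon bound to the aromatic nitrogen of the shared core proves sensitive to what it carries: a 6.1-fold higher number from compound 3 to compound 4 (0.78 log units; beyond the scatter) is the first single-place step, and it lies beyond the scatter. The step arises although 3-aminopropyl and carbamoyl count alike in hydrogen-bond donors and acceptors and neither is counted with a net charge, so those counts do not separate the two compounds; what the count does show is one heavy atom fewer, an oxygen and a double bond entering, and no nitrogen-free change at the chain end. Cut one bond further out, the same difference reads 4-aminobutyl to carbamoylmethyl, so chain length and end group change together here, and no measurement on hand accounts for the step.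

A shorter chain ending in an amine, or a longer chain ending in a carbamoyl, would show which of the two changes carries the step. As far as these compounds go, a carboxylic acid at the chain end, and whether the step holds on the cores of compound 1 and compound 2, also remain open.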